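Swapping Nitro for Phenyl on an Acid Ceramidase Inhibitor Core

The source may report more compounds than this note shows. Statements on the series, on what has been measured and on what is new or still open speak of the compounds shown alone.

Compound 1, `O=C(c1ccc(Cl)cc1)c1ccc2c(c1)oc(=O)n2C(=O)NCCCCc1ccccc1`, gives 14 nM in an assay on HEK293 cells for inhibition of acid ceramidase (Homo sapiens), with a stated time of 10 min; a higher number here means a weaker inhibitor, a lower number a stronger inhibitor.
Compound 2, `O=C(c1ccccc1)c1ccc2c(c1)oc(=O)n2C(=O)NCCCCc1ccccc1`, gives 29 nM in this assay.
Compound 3, `O=C(NCCCCc1ccccc1)n1c(=O)oc2cc([N+](=O)[O-])ccc21`, gives 3 nM in this assay.

Among these three, compound 3 stands lowest in this assay, and both of its gaps lie beyond the scatter: a 4.7-fold lower number from compound 1 to compound 3 (0.67 log units; beyond the scatter) and a 9.7-fold lower number from compound 2 to compound 3 (0.99 log units; beyond the scatter). The remaining step, a 2.1-fold higher number from compound 1 to compound 2 (0.32 log units; beyond the scatter), is smaller and concerns only the chloro.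

Compound 4, `O=C(NCCCCc1ccccc1)n1c(=O)oc2cc(-c3ccccc3)ccc21`, has not yet been measured in this assay. Going by the values given here, its single difference from compound 3 is phenyl in place of nitro on an aromatic carbon. Among the compounds with values here, no measured step makes exactly this change, but the two steps that bear on it are the ones in which the nitro was exchanged for an aryl carbonyl, and in both the number rose by a modest amount when read in the direction from nitro to aryl group. A phenyl is likewise a carbon-only aromatic ring in the same place, so a modest rise in the number, beyond the scatter, is expected for compound 4, on the order of an 8.3-fold higher number from compound 3 to compound 4 (0.92 log units; beyond the scatter). Compound 4 is therefore estimated at 25 nM, within a range from 8 nM to 80 nM.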

Compound 4, half-maximal inhibitory concentration: 84 nM
Compound 4: the middle estimate sits 3.4-fold (0.53 log units) below what was measured, and the stated range ends below it.
By their numbers in this assay, from the lowest: compound 3; then compound 1; then compound 2; then compound 4.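

At this aromatic carbon, replacing the nitro with phenyl gives the largest step in the series, a 28-fold higher number from compound 3 to compound 4 (1.45 log units; beyond the scatter) in this assay, so the position responds more strongly to this change than the two exchanges of nitro for an aryl carbonyl had shown. The carbonyl-linked and directly attached rings also read differently: a 2.9-fold higher number from compound 2 to compound 4 (0.46 log units; beyond the scatter) and a 6.0-fold higher number from compound 1 to compound 4 (0.78 log units; beyond the scatter) show that a phenyl set directly on the aromatic carbon gives a higher number than either aryl carbonyl group, which makes compound 4 the weakest of the four in this assay and places all three compounds with a carbon-only aromatic ring above compound 3. Nothing given here accounts for the size or direction of these steps.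

The compounds shown leave open how a nitrile, an amine or a carboxylic acid on this aromatic carbon would compare with the nitro of compound 3 in this assay. They also leave open whether a chloro on the phenyl of compound 4 would lower the number, as the chloro on the benzoyl group does in the pair read in reverse as a 2.1-fold higher number from compound 1 to compound 2 (0.32 log units; beyond the scatter).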